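Methyl on the benzyl ring: compound 2 to compound 3

A few compounds are considered here, and "the series" means these few. Any claim that something is new, unique, unknown or untested is made for them only; others in the source may bear on it.

Measured so far:
compound 1 `Cc1ccc(Cn2ccnc2/C=N/Nc2nc(NCCN(C)C)c3ccccc3n2)cc1`: 1410 nM
compound 2 `CN(C)CCCNc1nc(N/N=C/c2nccn2Cc2ccccc2)nc2ccccc12`: 1980 nM

In a functional assay on HT-29 cells (Homo sapiens) for cytotoxicity, read by MTT assay, with a stated time of 72 h (a higher number here means a weaker inhibitor, a lower number a stronger inhibitor), compound 2 gives 1980 nM, the highest of the two numbers, while compound 1 sits within the scatter of it. Compound 3 `Cc1ccc(Cn2ccnc2/C=N/Nc2nc(NCCCN(C)C)c3ccccc3n2)cc1` differs from compound 2 by methyl in place of hydrogen on an aromatic carbon. Within the data shown here, no such step has been measured here, so the expected step of a 1.2-fold lower number from compound 2 to compound 3 (0.09 log units; within the scatter) is small, in no firm direction, and likely within the scatter. Compound 1 also bears a 4-methylbenzyl group and gives 1410 nM, which supports this view. Compound 3 is therefore expected to give about 1600 nM, between 800 nM and 3200 nM.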

Compound 3, half-maximal inhibitory concentration: 2440 nM
Compound 3: middle estimate off by 1.5-fold (0.18 log units), on the low side, within the range that was stated.
By their numbers in this assay, from the lowest: compounds 1, 2 and 3 (each within the scatter of the next).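

In this assay, the change from benzyl to 4-methylbenzyl gives a 1.2-fold higher number from compound 2 to compound 3 (0.09 log units; within the scatter) and so stays within the scatter, which means this ring position carries a methyl with no measurable effect on the number. With the 4-methylbenzyl group held in place, (dimethylamino)methyl in place of dimethylamino on the chain gives a 1.7-fold higher number from compound 1 to compound 3 (0.24 log units; within the scatter) and also stays within the scatter. Nothing available here offers an explanation for either step. Going by these compounds, whether a chlorine or a methoxy group on this ring, or a chain ending in a morpholine ring, would produce a step beyond the scatter remains open.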